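Moving the fluorine on the aryl group of compound 2

This account rests on a few compounds, and the source may have more. Where it says the series, first, only, none or still open, it means among the compounds named here.

In an ADME assay on microsomes from liver (Homo sapiens) for metabolic stability, read by LC-MS (on this read-out higher numbers stand for a longer-lived compound and lower numbers for a shorter-lived compound), compound 1 (`Cc1nc(C)c(C(=O)Nc2ccc(F)c(-c3nc4ncc(-c5cccnc5Cl)cn4n3)c2)o1`) gives > 1.5 h as a limit of the assay, not a number. Going by the values given here, compound 2 (`O=C(Nc1ccc(F)c(-c2nc3ncc(-c4ccc(F)cc4)cc3[nH]2)c1)N1CCCC1`) gives 0.203 h as the only actual number so far. Compound 3 (`O=C(Nc1ccc(F)c(-c2nc3ncc(-c4ccccc4F)cc3[nH]2)c1)N1CCCC1`) carries 2-fluorophenyl in place of 4-fluorophenyl on an aromatic carbon and awaits measurement. Among the compounds with values here, no measured pair isolates such a change, so no shift beyond the scatter is expected in this assay. The expected move is a 1.0-fold lower number from compound 2 to compound 3 (0.01 log units; within the scatter) and no more. Compound 3 is estimated at 0.2 h with an expected range from 0.09 h to 0.45 h in this series.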

Compound 3, half-life: 0.285 h
Compound 3: the middle estimate sits 1.4-fold (0.15 log units) below what was measured; low and high end bracket the measured number.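

In this assay, moving the fluorine around the aryl group on this aromatic carbon gives a 1.4-fold higher number from compound 2 to compound 3 (0.15 log units; within the scatter), the first step read at this position. Exchanging 4-fluorophenyl for 2-fluorophenyl therefore leaves the half-life within the scatter. Nothing shown bears on a cause for this step.

On these data alone, whether a carboxylic acid or a primary amine on this aryl group would move the half-life beyond the scatter remains open. Going by these compounds alone, compound 1 differs from compound 2 and compound 3 in more than one place and gives no step at this position.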